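An Ethyl for a Methyl on the Ring Amide Nitrogen

The source may hold more compounds than are shown below. What is called first, only, known or untested is meant among the compounds shown, and "the series" means these compounds.

The study turns on a small core shared by four compounds. Compound 1 `CN1C(=O)C(C2=NS(=O)(=O)c3cc(NS(C)(=O)=O)ccc3N2)=C(O)C2CCCC21` is the parent, and its result in an ADME assay on Huh-7 cells (Homo sapiens) for cytotoxicity, with a stated time of 72 h (a lower number here means that less compound is tolerated, a higher number that more compound is tolerated), is recorded only as "not determined" (no result reported). Two other compounds carry the same core with larger groups. In this assay compound 2 `Cc1cc(CN2C(=O)C(C3=NS(=O)(=O)c4cc(NS(C)(=O)=O)ccc4N3)=C(O)[C@H]3CCC[C@H]32)ccc1F` gives > 1000 nM, which is a limit of the measurement and not a number. Compound 3 `CS(=O)(=O)Nc1ccc2c(c1)S(=O)(=O)N=C(C1=C(O)[C@H]3CCC[C@H]3N(Cc3ccc(F)c(Cl)c3)C1=O)N2` in this assay likewise gives > 1000 nM, again a limit rather than a number. The step that the two limits leave unreadable from compound 2 to compound 3 is therefore unreadable; all that can be said is that (the limit of > 1000 nM in this assay, at which 2 of the 3 values shown sit). Compound 4 `CCN1C(=O)C(C2=NS(=O)(=O)c3cc(NS(C)(=O)=O)ccc3N2)=C(O)C2CCCC21` differs from compound 1 by methyl in place of hydrogen on a saturated chain carbon bound to an amide-type nitrogen in a ring, which, cut one bond further out, reads methyl to ethyl. Going by the values given here, no measured step touches this change, and compound 1 itself has no number, so no shift beyond the scatter can be expected in either direction. Compound 4 is estimated to give 2000 nM in this assay, with a range from 600 nM to 6000 nM, and most probably the result will again be a limit.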

Compound 4, half-maximal cytotoxic concentration: > 33000 nM
Compound 4 gave a limit, no number (the forecaster's own chance of this, stated with the estimate: 75%); at least 16-fold (1.21 log units) between middle value and limit.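

In this assay compound 4 gives > 33000 nM, which is a limit and not a number. With compound 1 recorded as "not determined" (no result reported), no step can be read between compound 1 and compound 4. The compounds shown leave open what the change from methyl to ethyl does in this assay.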